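The compounds below may be only part of what the source reports. "The series", "measured", "known", "first", "only" and "open" are said of these compounds alone.

Measured so far in an assay on isolated protein for inhibition of aldehyde dehydrogenase 1A1 (Homo sapiens), read by spectrophotometry, tested at 10 uM; on this read-out higher numbers stand for more inhibition at the one concentration tested (going by the name of the read-out) and lower numbers for less inhibition:
- compound 1 `Cc1cccc(Cn2c(CN3CCN(C(=O)c4ccc([N+](=O)[O-])cc4)CC3)nc3ccccc32)c1`: 24.3%
- compound 2 `Cc1cccc(Cn2c(CN3CCN(C(=O)c4cccnc4)CC3)nc3ccccc32)c1`: 24.5%
- compound 3 `Cc1cccc(Cn2c(CN3CCN(C(=O)c4ccc(Br)cc4)CC3)nc3ccccc32)c1`: 25.8%

On these numbers compound 3 stands highest of the three, but the steps of a number 1.3 percentage points higher from compound 2 to compound 3 (within the scatter) and a number 1.5 percentage points higher from compound 1 to compound 3 (within the scatter) both lie within the scatter, and so does a number 0.2 percentage points higher from compound 1 to compound 2 (within the scatter); no order among the three can be stated, and the whole set reads as one flat level in this assay.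

Compound 4 `Cc1cccc(Cn2c(CN3CCN(C(=O)C(C)C)CC3)nc3ccccc32)c1` differs from compound 3 in one place: isopropyl in place of 4-bromophenyl on a carbonyl carbon. Among the compounds with values here, none of the measured steps bears directly on this change: each swaps one aromatic group for another, or one ring substituent for another, on the same carbonyl carbon, and none removes the aromatic group altogether. What the three values show is that this assay has so far not responded to the nature of the aromatic group, all within the scatter.

Lacking any step of this kind, the expectation is a step of about the scatter or less, and a wider range is allowed for the untested change: a number 4.8 percentage points lower from compound 3 to compound 4 (within the scatter). Compound 4 is therefore estimated at 21%, within 6% to 36%.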

Compound 4, a percentage reported as inhibition, at one concentration (the size of the read-out at that concentration, not a potency): 87.2%
Estimate against measurement, compound 4: 66.2 percentage points below; measured number outside the range, above it.
By their numbers in this assay, from the lowest: compounds 1, 2 and 3 (each within the scatter of the next); then compound 4.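

Isopropyl in place of an aromatic group on this carbonyl carbon gives a number 61.4 percentage points higher from compound 3 to compound 4 (beyond the scatter) and a number 62.7 percentage points higher from compound 2 to compound 4 (beyond the scatter) and also a number 62.9 percentage points higher from compound 1 to compound 4 (beyond the scatter) in this assay at this position. The flat level of compound 1, compound 2 and compound 3 therefore holds only among the three aromatic groups, and this position is not indifferent to what the carbonyl carbon carries. Nothing among the data shown accounts for the size of this jump.

With isopropyl as the only non-aromatic group, the compounds shown do not separate the loss of the aromatic ring from the change to a group with fewer heavy atoms. Cyclohexyl on the same carbonyl carbon would keep a ring without aromatic character, while methyl or a longer chain such as n-butyl would show how far the level depends on the size of the chain.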